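Methylating a Phenolic Oxygen: Expected Effect on Cytotoxicity

The source may hold more compounds than are shown below. What is called first, only, known or untested is meant among the compounds shown, and "the series" means these compounds.

Measured so far in a functional assay on HOP-62 cells (Homo sapiens) for cytotoxicity, read by resazurin assay, with a stated time of 72 h; on this read-out lower numbers stand for stronger inhibition and higher numbers for weaker inhibition:
compound 1 `O=C(/C=C/c1ccc(OCCCCO[N+](=O)[O-])c(O)c1)OCCCCO[N+](=O)[O-]` gives > 50000 nM.
compound 2 `COc1cc(/C=C/C(=O)OCCCO[N+](=O)[O-])ccc1O` gives 19400 nM.

The value for compound 1 is a limit of the assay, not a number: it sits at the limit of > 50000 nM in this assay, at which 1 of the 2 values shown sits, meaning compound 1 showed no measurable inhibition within the tested range. Compound 2 does return a number, but it differs from compound 1 in more than one place, so the two values cannot be read as a single step.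

Compound 3 `COc1cc(/C=C/C(=O)OCCCCO[N+](=O)[O-])ccc1OCCCCO[N+](=O)[O-]` differs from compound 1 in one place: methyl in place of hydrogen on an oxygen on an aromatic ring, that is, hydroxy to methoxy. Among the measured compounds shown here, no measured pair shows this change on its own, so its size is not known from these data. In this assay the step of an at least 1.2-fold lower number from compound 1 to compound 3 (0.09 log units; that floor lies within the scatter) is expected to be small, likely within the scatter. Compound 3 is therefore estimated at 40000 nM, in a range from 12000 nM to 130000 nM.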

Compound 3, half-maximal inhibitory concentration: > 50000 nM
Compound 3: a limit, no number; the forecaster's own chance of this, stated with the estimate: 50%; middle value at least 1.2-fold (0.09 log units) from the limit.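

Compound 3 gives > 50000 nM, a limit and not a number, and compound 1 sits at the same limit, so the step between them cannot be read: the limit of > 50000 nM in this assay, at which 2 of the 3 values shown sit.

The compounds shown leave open what methyl in place of hydrogen on this oxygen does on its own to cytotoxicity.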